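Heteroaryl exchange on the saturated chain carbon, compound 3

A few compounds are considered here, and "the series" means these few. Any claim that something is new, unique, unknown or untested is made for them only; others in the source may bear on it.

Compound 2 `c1cc(Cn2cccn2)c2c(c1)[C@H](c1ncc[nH]1)CC2` is one of two measured members of the series. In a functional assay on CHO cells for agonist activity at Alpha-1A adrenergic receptor (Homo sapiens), read by fluorescence and calcium flux (a higher number here means a larger maximal response, a lower number a smaller maximal response), compound 2 gives 69%. Compound 1 `COCc1cccc2c1CC[C@H]2c1ncc[nH]1` gives 69% in this assay, and the step of no change at the digits printed from compound 1 to compound 2 (within the scatter) left compound 2 level with compound 1. Compound 2 therefore stands level with its nearest neighbour; nothing in the two values separates them.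

Compound 3 `Cc1noc(Cc2cccc3c2CC[C@H]3c2ncc[nH]2)n1` is not yet measured. It differs from compound 2 by 3-methyl-1,2,4-oxadiazol-5-yl in place of 1H-pyrazol-1-yl on a saturated chain carbon bound to an aromatic carbon. Going by the values given here, the only measured step, no change at the digits printed from compound 1 to compound 2 (within the scatter), exchanged the group on the saturated chain carbon bound to an aromatic carbon without moving the maximal response. That step bears on compound 3 in that it touches the same place, though the group that enters here is a different one. On that basis no step beyond the scatter is expected in this assay, and the estimate for compound 3 is 69%, with a range from 55% to 83%. The expected step of no change at the digits printed from compound 2 to compound 3 (within the scatter) is flat within the scatter. Among the compounds with values here, only one measured step is available, and the range is kept wide to reflect that.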

Compound 3, largest response reached (Emax), in percent of the reference or control that the assay uses in the Alpha-1A adrenergic receptor assay: 44%
The estimate for compound 3 lay 25 percentage points above the measured number; measured number below the stated range.
By their numbers in the Alpha-1A adrenergic receptor assay, from the lowest: compound 3; then compounds 1 and 2 (each within the scatter of the next).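

The saturated chain carbon bound to an aromatic carbon is not indifferent to the group it carries: in the Alpha-1A adrenergic receptor assay the exchange for 3-methyl-1,2,4-oxadiazol-5-yl gives a number 25 percentage points lower from compound 2 to compound 3 (beyond the scatter) and a number 25 percentage points lower from compound 1 to compound 3 (beyond the scatter), whereas methoxy and 1H-pyrazol-1-yl had stood level there. The earlier flat step therefore did not extend to every group at this place, and of the three groups compared, only 3-methyl-1,2,4-oxadiazol-5-yl stands apart in maximal response. In a physicochemical assay for lipophilicity, at pH 7.4 (a lower number here means a more polar compound, a higher number a more lipophilic compound), compound 2 gives 1.8 and compound 3 gives 2, a pair within the scatter of each other, and no information is available on the origin of the lower maximal response.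

Still open, from the compounds shown here alone, is whether the lower response goes with the 1,2,4-oxadiazole ring itself or with its methyl group, which the plain 1,2,4-oxadiazol-5-yl group would help to separate. Equally open is how groups of another kind on the same saturated chain carbon, such as a primary amine or a carboxylic acid, would sit relative to these three in the Alpha-1A adrenergic receptor assay, since the series shown holds only ethers and five-membered aromatic rings at this place.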